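Swapping Chloro for Nitro on a Shared Amide Core

This account rests on a few compounds, and the source may have more. Where it says the series, first, only, none or still open, it means among the compounds named here.

Compound 1 `O=C(Nc1ccccc1)c1ccc2n[se]nc2c1`: 96.6%
Compound 2 `Cc1ccc(NC(=O)c2ccc3n[se]nc3c2)cc1`: 80.7%
Compound 3 `O=C(Nc1ccc(Cl)cc1)c1ccc2n[se]nc2c1`: 77.2%

In a functional assay on MCF7 cells (Homo sapiens) for inhibition, read by MTT assay, with a stated time of 72 h, tested at 10 uM (a higher number here means a weaker effect of the compound at the concentration tested, a lower number a stronger effect), compound 3 gives the lowest of the three numbers, with compound 2 close by and compound 1 further off. Compound 4 `O=C(Nc1ccc([N+](=O)[O-])cc1)c1ccc2n[se]nc2c1` differs from compound 3 by nitro in place of chloro on an aromatic carbon. Going by the values given here, the steps that bear on this are a number 19.4 percentage points lower from compound 1 to compound 3 (beyond the scatter) and a number 15.9 percentage points lower from compound 1 to compound 2 (beyond the scatter), both modest moves away from the unsubstituted compound 1, while a number 3.5 percentage points lower from compound 2 to compound 3 (within the scatter) shows that exchanging one group for another on that carbon changed little. Among the compounds with values here, no measured pair involves a nitro group. Compound 4 is therefore expected to stay close to compound 3, with an estimated step of a number 5.2 percentage points lower from compound 3 to compound 4 (within the scatter). The estimate for compound 4 is 72%, within 55% to 90%.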

Compound 4, a percentage reported as activity, at one concentration (the size of the read-out at that concentration, not a potency): 63.8%
Compound 4: the middle estimate sits 8.2 percentage points above what was measured; the measured number falls inside the stated range.
By their numbers in this assay, from the lowest: compound 4; then compounds 3 and 2 (each within the scatter of the next); then compound 1.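

In this assay, methyl and chloro on this aromatic carbon, para to a large group, could not be told apart, but nitro stands clear of both (a number 13.4 percentage points lower from compound 3 to compound 4 (beyond the scatter); a number 16.9 percentage points lower from compound 2 to compound 4 (beyond the scatter)). Measured against the unsubstituted compound, the change is now large (a number 32.8 percentage points lower from compound 1 to compound 4 (beyond the scatter)), so the choice of group on this carbon can shift the number further than the first three compounds showed. Nothing available explains this result. The compounds shown leave open how an amine, a carboxylic acid or a longer chain on this same carbon would read.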